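Removing the bromo from a benzylurea: expected half-life

A few compounds are considered here, and "the series" means these few. Any claim that something is new, unique, unknown or untested is made for them only; others in the source may bear on it.

The study looks at two close analogues and a third compound yet to be measured. Compound 1 `COc1cccc(CNC(=O)N2C(=O)c3ccccc3S2(=O)=O)c1` gives 0.523 h in a physicochemical assay for pharmacokinetics; on this read-out higher numbers stand for a longer-lived compound and lower numbers for a shorter-lived compound. Compound 2 `O=C(NCc1cccc(Br)c1)N1C(=O)c2ccccc2S1(=O)=O` gives 0.492 h in this assay, and the step of a 1.1-fold lower number from compound 1 to compound 2 (0.03 log units; within the scatter) places the two within the scatter of one another. Compound 3 `O=C(NCc1ccccc1)N1C(=O)c2ccccc2S1(=O)=O` differs from compound 2 by hydrogen in place of bromo on an aromatic carbon. For the measured compounds named here, no measured step removes a group from that carbon; the only step, a 1.1-fold lower number from compound 1 to compound 2 (0.03 log units; within the scatter), swaps one group for another and leaves the number unchanged, so no step beyond the scatter is expected in this assay. For compound 3 the expected value is 0.5 h (range 0.3 h to 0.85 h), an expected step of a 1.0-fold higher number from compound 2 to compound 3 (0.01 log units; within the scatter).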

Compound 3, half-life: 1.02 h
Compound 3: middle estimate off by 2.0-fold (0.31 log units), on the low side, outside the stated range (above it).
By their numbers in this assay, from the lowest: compounds 2, 1 and 3 (each within the scatter of the next, the first and the last beyond it).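

In this assay, hydrogen in place of bromo gives a 2.1-fold higher number from compound 2 to compound 3 (0.32 log units; beyond the scatter) and so shows that this aromatic carbon does respond to a change, which the swap of one group for another had not shown. Hydrogen in place of methoxy on the same carbon gives a 2.0-fold higher number from compound 1 to compound 3 (0.29 log units; within the scatter) and stays inside the scatter, so only the bromo comparison is a clear step, and a modest one. Nothing available accounts for this step.
As far as these compounds go, whether a fluoro or an amine on that carbon would read like bromo or like hydrogen stays open. So does whether the step from 3-bromophenyl to phenyl would hold on another core.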